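This account rests on a few compounds, and the source may have more. Where it says the series, first, only, none or still open, it means among the compounds named here.

Compound 1 `CCn1c(C(=O)NCC#N)ccc1C(CC)(CC)c1ccc(OCCC(O)(CC)CC)c(C)c1`: > 50000 nM, a limit.
Compound 2 `CCn1c(C(=O)NCCN)ccc1C(CC)(CC)c1ccc(OCCC(O)(CC)CC)c(C)c1`: 1740 nM.
Compound 3 `CCn1c(C(=O)N(CCC#N)CCC#N)ccc1C(CC)(CC)c1ccc(OCCC(O)(CC)CC)c(C)c1`: > 50000 nM, a limit.

All values come from a functional assay on Caco-2 cells (Homo sapiens) for antiproliferative activity, read by MTT assay, with a stated time of 48 h; a higher number here means a weaker inhibitor, a lower number a stronger inhibitor. Compound 3 stands at a limit of this assay, > 50000 nM, and gives no number. The next structure is compound 4 `C=CCN(C)C(=O)c1ccc(C(CC)(CC)c2ccc(OCCC(O)(CC)CC)c(C)c2)n1CC`, and the change is a group of 5 heavy atoms (4 carbon, 1 nitrogen; no ring) in place of a group of 9 heavy atoms (6 carbon, 3 nitrogen; no ring), on a carbonyl carbon. Among the measured compounds shown here, the only readable steps both involve compound 2, and both are large: an at least 28-fold lower number from compound 1 to compound 2 (1.45 log units; beyond the scatter), and an at least 28-fold higher number from compound 2 to compound 3 (1.45 log units; beyond the scatter). The step that the two limits leave unreadable from compound 1 to compound 3 cannot be read. Compound 4 lacks the aminomethyl group of compound 2, so no comparable drop is expected, only a small lowering or none. The expected change is an at least 1.4-fold lower number from compound 3 to compound 4 (0.15 log units; that floor lies within the scatter). For compound 4 the estimated value is 35000 nM. The expected range runs from 10000 nM to 60000 nM.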

Compound 4, half-maximal inhibitory concentration: > 50000 nM
Compound 4: only a limit was reported; the forecaster's own chance of this, stated with the estimate: 55%; at least 1.4-fold (0.15 log units) between middle value and limit.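

Compound 4 carries no nitrile in its allyl(methyl)amino group on the carbonyl carbon, yet it too reports only a limit, so the limit is not confined to the nitrile-bearing groups of compound 1 and compound 3. Against the (2-aminoethyl)amino group, the change gives an at least 28-fold higher number from compound 2 to compound 4 (1.45 log units; beyond the scatter). The steps to compound 4 from compound 1 and compound 3 cannot be read, and compound 2 remains the only compound with a number: the limit of > 50000 nM in this assay, at which 3 of the 4 values shown sit.

From the compounds shown here alone, what stays open is whether a terminal amine on the chain is what sets compound 2 apart. A 3-aminopropyl chain, a dimethylaminoethyl group or a carboxylic acid at this carbonyl carbon would bear on that.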